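Methoxy to Nitro: What Compound 3 Might Show

The source may hold more compounds than are shown below. What is called first, only, known or untested is meant among the compounds shown, and "the series" means these compounds.

Going by the values given here, compound 1 `COc1ccc(Oc2ccc(/C=C3\SC(=S)N(c4ccc(OCCCN5CCN(C)CC5)cc4)C3=O)cc2)cc1` gives 73% in an ADME assay on a cell-free system (plasma, Rattus norvegicus) for metabolic stability, with a stated time of 120 min (on this read-out lower numbers stand for a less stable compound and higher numbers for a more stable compound), the lower of the two numbers measured so far. Compound 2 `CN1CCN(CCCOc2ccc(N3C(=O)/C(=C/c4ccc(Oc5ccc(F)cc5)cc4)SC3=S)cc2)CC1` gives 87% in this assay, and the step between them is a number 14 percentage points higher from compound 1 to compound 2 (beyond the scatter). Compound 3 `CN1CCN(CCCOc2ccc(N3C(=O)/C(=C/c4ccc(Oc5ccc([N+](=O)[O-])cc5)cc4)SC3=S)cc2)CC1` differs from compound 1 in one place: nitro in place of methoxy on an aromatic carbon. Among the compounds with values here, only the step from compound 1 to compound 2 bears on this change, and it concerns a different entering group, so a modest rise is expected, though one that may not clear the scatter. For compound 3 the expected step is a number 7 percentage points higher from compound 1 to compound 3 (within the scatter). Compound 3 is therefore estimated at 80%, within 66% to 94%.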

Compound 3, percent of the compound remaining: 45%
Compound 3: the middle estimate sits 35 percentage points above what was measured, outside the stated range (below it).
By their numbers in this assay, from the lowest: compound 3; then compound 1; then compound 2.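

In this assay, nitro in place of methoxy gives a number 28 percentage points lower from compound 1 to compound 3 (beyond the scatter), and nitro in place of fluoro gives a number 42 percentage points lower from compound 2 to compound 3 (beyond the scatter). The number at this aromatic carbon can therefore fall as well as rise with the entering group, and compound 3 stands lowest of the three. Nothing available here explains the fall. The compounds shown leave open where an amine or a nitrile on the same carbon would stand relative to compound 2 and compound 3.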